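The compounds below may be only part of what the source reports. "The series", "measured", "known", "first", "only" and "open" are said of these compounds alone.

Compound 1 `COc1nc(Cl)nc(C)c1CCO` gives > 100000 nM in a functional assay on NCI-H460 cells (Homo sapiens) for antiproliferative activity, read by MTT assay, with a stated time of 24 h (on this read-out higher numbers stand for weaker inhibition and lower numbers for stronger inhibition), a limit of the assay.
Compound 2 `COc1nc(Cl)nc(C)c1CCF` gives > 100000 nM in this assay, also a limit.
Compound 3 `COc1nc(C)c(CCOC(C)=O)c(OC)n1` gives 47000 nM in this assay.

For the measured compounds named here, of the three measured compounds, compound 3 is the only one with a number in this assay; the other two sit at the limit of > 100000 nM in this assay, at which 2 of the 3 values shown sit. The step from compound 1 to compound 2, a step that the two limits leave unreadable from compound 1 to compound 2, cannot be sized for that reason.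

Compound 4 `COc1nc(Cl)nc(C)c1CCOC(C)=O` is not yet measured. It differs from compound 3 by chloro in place of methoxy on an aromatic carbon. Going by the values given here, no measured step involves this change, so none bears on it directly. What can be said is that compound 4 carries the same chloro-bearing core as compound 1 and compound 2, and both of those returned only a limit in this assay, whereas compound 3, with methoxy at that position, returned a number.

On that basis compound 4 is expected to be weaker than compound 3 in this assay, with a step of about a 2.6-fold higher number from compound 3 to compound 4 (0.41 log units; beyond the scatter). The estimate for compound 4 is 120000 nM, within a range from 40000 nM to 400000 nM, and it may well be reported only as a limit.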

Compound 4, half-maximal inhibitory concentration: > 100000 nM
Compound 4: no number, only a limit (the forecaster's own chance of this, stated with the estimate: 60%); the middle value does not contradict the limit.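

In this assay, the result gives the first size for this change: with the acetoxy chain held fixed, chloro in place of methoxy on the aromatic carbon between two ring nitrogen atoms brings an at least 2.1-fold higher number from compound 3 to compound 4 (0.32 log units; beyond the scatter). Compound 4 stands at a limit, so that size is only a lower bound, and its steps from compound 1 and compound 2 cannot be read, since all three values are limits. With chloro at this position, the hydroxy, fluoro and acetoxy chains all end at the same place: the limit of > 100000 nM in this assay, at which 3 of the 4 values shown sit.

Still open, on these data alone, is whether an amine or an ethoxy group at this position would give a number as methoxy does. Also open, as far as these compounds go, is how a carboxylic acid or a longer chain in place of the acetoxy chain would read with methoxy kept.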